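From 4-methylbenzyl to 2,4-dichlorobenzyl: an expected step

The compounds below may be only part of what the source reports. "The series", "measured", "known", "first", "only" and "open" are said of these compounds alone.

For the measured compounds named here, only two compounds have numbers so far. In a functional assay on MDA-MB-231 cells (Homo sapiens) for cytotoxicity, read by MTT assay, with a stated time of 72 h (a lower number here means a stronger inhibitor, a higher number a weaker inhibitor), compound 1 `CN(C)Cc1ccc2nc(NC(=O)N/N=C/c3cn(Cc4ccccc4Cl)c4ccccc34)sc2c1` gives 1180 nM and compound 2 `Cc1ccc(Cn2cc(/C=N/NC(=O)Nc3nc4ccc(CN(C)C)cc4s3)c3ccccc32)cc1` gives 1220 nM, so compound 2 sits level with compound 1 within the scatter.

The next compound is compound 3 `CN(C)Cc1ccc2nc(NC(=O)N/N=C/c3cn(Cc4ccc(Cl)cc4Cl)c4ccccc34)sc2c1`, reached from compound 2 by the change (2,4-dichlorophenyl in place of 4-methylphenyl on a saturated chain carbon bound to an aromatic nitrogen). In words, 2,4-dichlorophenyl stands in place of 4-methylphenyl on a saturated chain carbon bound to an aromatic nitrogen.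

Going by the values given here, one measured step bears on this, at the same place on the shared core: a 1.0-fold higher number from compound 1 to compound 2 (0.01 log units; within the scatter). That exchange of 2-chlorophenyl for 4-methylphenyl left the number within the scatter. Among the compounds with values here, a single step is thin evidence, and no measured compound yet carries two chlorines on this ring. Even so, the flat step from compound 1 to compound 2 gives no ground for expecting a move in either direction in this assay beyond the scatter.

The expected change is small, an estimated 1.2-fold lower number from compound 2 to compound 3 (0.09 log units; within the scatter). For compound 3 the expected value is 1000 nM, with an estimated range of 450 nM to 2200 nM.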

Compound 3, half-maximal inhibitory concentration: 1410 nM
Estimate against measurement, compound 3: 1.4-fold (0.15 log units) below, and the stated range covers the measured number.
By their numbers in this assay, from the lowest: compounds 1, 2 and 3 (each within the scatter of the next).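

In this assay, 2,4-dichlorophenyl in place of 4-methylphenyl on a saturated chain carbon bound to an aromatic nitrogen gives a 1.2-fold higher number from compound 2 to compound 3 (0.06 log units; within the scatter), and chloro in place of hydrogen on an aromatic carbon gives a 1.2-fold higher number from compound 1 to compound 3 (0.08 log units; within the scatter). For the compounds shown here, the earlier pair showed only one exchange of a single substituted phenyl for another; this result adds a ring with two chlorines and a comparison that differs by one chloro alone, and neither step leaves the scatter, so compound 1, compound 2 and compound 3 stand level at this position. No measurement is available that could tie this lack of a shift to any property of these groups.

From the compounds shown here alone, all three groups at this position are substituted phenyl rings on the same saturated chain carbon, so it remains open whether a carboxylic acid or an amine on that ring, or a longer chain in place of that carbon, would give a step beyond the scatter. Going by these compounds, it also remains open whether the same level picture would hold for changes elsewhere on the shared core.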